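A few compounds are considered here, and "the series" means these few. Any claim that something is new, unique, unknown or untested is made for them only; others in the source may bear on it.

Measured so far in a functional assay on OVCAR-8 cells (Homo sapiens) for antiproliferative activity, read by MTT assay, with a stated time of 72 h; on this read-out lower numbers stand for stronger inhibition and higher numbers for weaker inhibition:
- compound 1 `O=C(Nc1cccc(F)c1)c1cc(=O)[nH]c2cc(-c3ccc(F)cc3)ccc12`: 22300 nM
- compound 2 `O=C(Nc1cccc(F)c1)c1cc(=O)[nH]c2cc(-c3ccsc3)ccc12`: 13400 nM

Not yet measured:
- compound 3 `O=C(Nc1cccc(F)c1)c1cc(=O)[nH]c2cc(C3=CCOCC3)ccc12`

For the measured compounds named here, with only two numbers available, compound 2 cannot be separated from compound 1: the single measured step, a 1.7-fold lower number from compound 1 to compound 2 (0.22 log units; within the scatter), lies within the scatter. That step exchanged one aromatic ring for another on an aromatic carbon.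

Compound 3 is changed on that same carbon: a group of 6 heavy atoms (5 carbon, 1 oxygen; one six-membered non-aromatic ring with 1 hetero atom) in place of a group of 5 heavy atoms (4 carbon, 1 sulfur; one five-membered aromatic ring with 1 hetero atom), on an aromatic carbon. The carbon belongs to a six-membered aromatic ring of carbon only, part of a fused or bridged system of two rings. Going by the values given here, the new group differs more from the earlier ones, since it is non-aromatic, and no measured compound carries such a ring there. Among the compounds with values here, the one step, a 1.7-fold lower number from compound 1 to compound 2 (0.22 log units; within the scatter), is therefore only a weak guide. It gives no direction, so no shift beyond the scatter is expected in this assay. The expected step is a 1.5-fold higher number from compound 2 to compound 3 (0.17 log units; within the scatter), and this remains uncertain. The estimate for compound 3 is 20000 nM, with an expected range of 8000 nM to 50000 nM.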

Compound 3, half-maximal inhibitory concentration: 21800 nM
Compound 3: the middle estimate sits 1.1-fold (0.04 log units) below what was measured; low and high end bracket the measured number.
By their numbers in this assay, from the lowest: compounds 2, 3 and 1 (each within the scatter of the next).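

In this assay, the ring with the single hetero atom and a double bond outside aromatic rings gives a 1.6-fold higher number from compound 2 to compound 3 (0.21 log units; within the scatter) and a 1.0-fold lower number from compound 1 to compound 3 (0.01 log units; within the scatter) at this aromatic carbon. The earlier pair covered only aromatic rings; these steps extend the finding to a six-membered non-aromatic ring, and the three compounds cannot be separated, so within this set an aromatic ring on this carbon is not needed for a number in this range. No available measurement explains why these three groups cannot be told apart.

As far as these compounds go, it remains open whether any group on this carbon can produce a step beyond the scatter in this assay, as all three compounds carry a single ring there and none has an amine, a carboxylic acid or a longer chain in that place. Also open, from the compounds shown here alone, is whether the same lack of separation would hold with a change elsewhere on the shared core, as all three compounds differ only on this carbon.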